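The compounds below may be only part of what the source reports. "The series", "measured", "known", "first", "only" and "open" are said of these compounds alone.

Three measured compounds share one core and differ only in the group attached to the carbonyl carbon of the side chain. Compound 1 `COc1ccc(-c2cc3ccccc3nc2/C=C/C(=O)c2ccccc2)cc1` carries a plain phenyl there and gives 7410 nM in a functional assay on A549 cells (Homo sapiens) for antiproliferative activity, read by XTT assay, with a stated time of 72 h; on this read-out lower numbers stand for stronger inhibition and higher numbers for weaker inhibition. Compound 2 `COc1ccc(-c2cc3ccccc3nc2/C=C/C(=O)c2ccc(O)cc2)cc1` adds a hydroxy group to that phenyl, and in this assay compound 2 gives 7440 nM. Compound 3 `COc1ccc(-c2cc3ccccc3nc2/C=C/C(=O)c2ccco2)cc1` carries a furan-2-yl instead, and in this assay compound 3 gives 6130 nM. On these numbers compound 3 stands together with the other two: the step of a 1.2-fold lower number from compound 1 to compound 3 (0.08 log units; within the scatter) and the step of a 1.2-fold lower number from compound 2 to compound 3 (0.08 log units; within the scatter) are both within the scatter, as is the step of a 1.0-fold higher number from compound 1 to compound 2 (0.00 log units; within the scatter). None of the three exchanges at the carbonyl carbon has shifted the read-out beyond what repeated measurements would show.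

Compound 4 `COc1ccc(-c2cc3ccccc3nc2/C=C/C(=O)c2ccsc2)cc1` continues this series with one change: thiophen-3-yl in place of furan-2-yl on a carbonyl carbon. For the measured compounds named here, the steps that bear on it are the two earlier swaps at the same carbonyl carbon, both within the scatter, so no step beyond the scatter in this assay is expected in either direction; the expected step is a 1.1-fold higher number from compound 3 to compound 4 (0.03 log units; within the scatter). Compound 4 is therefore estimated at 6500 nM, with a range from 3000 nM to 14000 nM.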

Compound 4, half-maximal inhibitory concentration: 8210 nM
Beside the measured number, compound 4's estimate is 1.3-fold (0.10 log units) below it; measured number inside the range.
By their numbers in this assay, from the lowest: compounds 3, 1, 2 and 4 (each within the scatter of the next).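

In this assay, a ring carrying sulfur at the carbonyl carbon leaves the read-out within the scatter of all three earlier groups: this holds for the step of a 1.3-fold higher number from compound 3 to compound 4 (0.13 log units; within the scatter), the step of a 1.1-fold higher number from compound 2 to compound 4 (0.04 log units; within the scatter) and the step of a 1.1-fold higher number from compound 1 to compound 4 (0.04 log units; within the scatter). The flat picture therefore now spans four aromatic groups, phenyl, 4-hydroxyphenyl, furan-2-yl and thiophen-3-yl, and no compound shown goes against it, so exchanging oxygen for sulfur in a five-membered aromatic ring, along with the change from a 2-yl to a 3-yl group, gives no step beyond the scatter at this position. Nothing measured here explains why these exchanges make so little difference.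

As far as these compounds go, every group tested at this carbonyl carbon is an aromatic ring, so it remains open whether an amine, a carboxylic acid or a longer alkyl chain there would give a number beyond the scatter. From the compounds shown here alone, it also remains open whether replacing the methoxy group of the shared core with a hydroxy group or a chlorine atom would move the read-out more than any change at the carbonyl carbon has.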